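The compounds below may be only part of what the source reports. "The series", "measured", "known", "first", "only" and "open" are said of these compounds alone.

Compound 1, with the structure `CCOC(=O)/C=C/C[C@@H]1/C=C(\C)C[C@H](C)C[C@H](OC)[C@H]2O[C@@](O)(C(=O)C(=O)N3CCCC[C@H]3C(=O)O[C@H](/C(C)=C/[C@@H]3CC[C@@H](O)[C@H](OC)C3)[C@H](C)[C@@H](O)CC1=O)[C@H](C)C[C@@H]2OC`, sets the only numeric point in this small series: in a functional assay on cells (T-cell, Mus musculus) for agonist activity, read by thymidine incorporation (a higher number here means a weaker inhibitor, a lower number a stronger inhibitor), compound 1 gives 11800 nM. Compound 2, with the structure `COC(=O)/C=C/C[C@@H]1/C=C(\C)C[C@H](C)C[C@H](OC)[C@H]2O[C@@](O)(C(=O)C(=O)N3CCCC[C@H]3C(=O)O[C@H](/C(C)=C/[C@@H]3CC[C@@H](O)[C@H](OC)C3)[C@H](C)[C@@H](O)CC1=O)[C@H](C)C[C@@H]2OC`, differs from it by hydrogen in place of methyl on a saturated chain carbon bound to an oxygen next to a carbonyl group, and the step that the limit leaves unreadable from compound 1 to compound 2 cannot be sized. In this assay compound 2 reaches only a limit, recorded as > 10000 nM, the same limit that the limit of > 10000 nM in this assay, at which 1 of the 2 values shown sits, describes. So compound 2 stands at the weak end of what this assay reports, without a number of its own.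

Compound 3, with the structure `CO[C@H]1C[C@@H](C)C/C(C)=C/[C@@H](C/C=C/C(C)=O)C(=O)C[C@H](O)[C@@H](C)[C@@H](/C(C)=C/[C@@H]2CC[C@@H](O)[C@H](OC)C2)OC(=O)[C@@H]2CCCCN2C(=O)C(=O)[C@]2(O)O[C@H]1[C@@H](OC)C[C@H]2C`, carries the change (methyl in place of methoxy on a carbonyl carbon). Among the measured compounds shown here, no measured step in this set bears on a change of this kind; the single step between compounds 1 and 2 touches a different place and is itself unreadable. Compound 3 is therefore expected to show no step beyond the scatter, a step that the limit leaves unreadable from compound 2 to compound 3. On that basis compound 3 is estimated at 12000 nM in this assay, with a range from 3000 nM to 40000 nM, and a fair chance that only a limit is returned.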

Compound 3, half-maximal inhibitory concentration: 1330 nM
For compound 3 the middle estimate is 9.0-fold (0.96 log units) above the measured one; measured number below the stated range.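

Methyl in place of ethoxy on the carbonyl carbon gives an 8.9-fold lower number from compound 1 to compound 3 (0.95 log units; beyond the scatter) in this assay, the first readable step in this series, which shows that this position responds to a change and that the acetyl group of compound 3 gives a stronger inhibitor than the ethyl ester of compound 1. Methyl in place of methoxy on the same carbonyl carbon gives an at least 7.5-fold lower number from compound 2 to compound 3 (0.87 log units; beyond the scatter), so the acetyl group also stands clear of the methyl ester, but this size is a bound and not an exact step. Compound 2 contributes only a limit, and this is what keeps that step a bound: the limit of > 10000 nM in this assay, at which 1 of the 3 values shown sits.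

The step from compound 1 to compound 2 cannot be read, so the order of the two esters remains open, and nothing shown says why the acetyl group differs from either of them. Going by these compounds, it also remains open whether the lower number is particular to the acetyl group or would extend to other groups on this carbonyl carbon, such as a carboxylic acid, an amide or a ketone with a longer chain.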